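Cyclobutyl to Pyrrolidin-3-yl: Toxicity Expected to Stay Undetectable

The source may hold more compounds than are shown below. What is called first, only, known or untested is meant among the compounds shown, and "the series" means these compounds.

The three measured compounds share one core and differ only in the group on an aromatic nitrogen. Compound 1 `COCCn1nc(C(=O)N[C@H]2COc3ccccc3N(C)C2=S)nc1Cc1ccccc1` carries a 2-methoxyethyl there; in a toxicity assay on HT-29 cells (Homo sapiens) for cytotoxicity (on this read-out higher numbers stand for lower toxicity in this test and lower numbers for higher toxicity in this test), compound 1 reaches only the assay limit of > 100000 nM. Compound 2 `CN1C(=S)[C@@H](NC(=O)c2nc(Cc3ccccc3)n(CCCC(F)(F)F)n2)COc2ccccc21` carries a 4,4,4-trifluorobutyl; in this assay compound 2 likewise gives only the limit > 100000 nM. Compound 3 `CN1C(=S)[C@@H](NC(=O)c2nc(Cc3ccccc3)n(C3CCC3)n2)COc2ccccc21`, with a cyclobutyl on that nitrogen, also stops at the limit in this assay, giving > 100000 nM. Accordingly the steps a step that the two limits leave unreadable from compound 1 to compound 2, a step that the two limits leave unreadable from compound 1 to compound 3 and a step that the two limits leave unreadable from compound 2 to compound 3 are all unreadable, and compound 3 stands where every measured value sits, at the limit of > 100000 nM in this assay, at which 3 of the 3 values shown sit.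

Compound 4 `CN1C(=S)[C@@H](NC(=O)c2nc(Cc3ccccc3)n(C3CCNC3)n2)COc2ccccc21` changes the same position: pyrrolidin-3-yl in place of cyclobutyl on an aromatic nitrogen. Going by the values given here, no measured step bears on this change in a readable way; each of the three steps runs between two limits. Compound 1, compound 2 and compound 3 all sit at the limit of > 100000 nM in this assay, at which 3 of the 3 values shown sit, and on that basis compound 4 is expected to remain at the limit as well. The estimated step of a number no higher from compound 3 to compound 4 (the limit leaves the size open) is therefore expected to be none beyond the scatter. The estimate for compound 4 in this assay is 100000 nM, ranging from 40000 nM to 300000 nM.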

Compound 4, half-maximal cytotoxic concentration: > 100000 nM
Compound 4: no number, only a limit; the forecaster's own chance of this, stated with the estimate: 85%; the middle value lies on the limit itself.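

In this assay compound 4 gives > 100000 nM, which is a limit of the assay and not a number. The steps from compound 1, compound 2 and compound 3 to compound 4 therefore cannot be read: the limit of > 100000 nM in this assay, at which 4 of the 4 values shown sit.

The compounds shown leave open whether any group on this aromatic nitrogen would give a measurable number in this assay.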